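Fluoro for Chloro in a Rat Artery Screen

The source may hold more compounds than are shown below. What is called first, only, known or untested is meant among the compounds shown, and "the series" means these compounds.

Measured compounds:
Compound 1, `CC1=C(C(=O)Nc2ccc(F)cc2)C(c2ccc([N+](=O)[O-])cc2)N=C(SCc2ccc(Cl)cc2)N1`, gives 22.2% in a functional assay on the whole organism (artery, strain albino) with Rattus norvegicus as the target, with a stated time of 720 min, at a dose of 10 mg/kg by the oral route; on this read-out higher numbers stand for more inhibition at the one dose given (going by the name of the read-out) and lower numbers for less inhibition.
Compound 2, `CC1=C(C(=O)Nc2ccc(F)cc2)C(c2ccc([N+](=O)[O-])cc2)N=C(SCc2ccc(F)cc2)N1`, gives 19.6%.
Compound 3, `CC1=C(C(=O)Nc2ccc([N+](=O)[O-])cc2)C(c2ccc(Br)cc2)N=C(SCc2ccc(Cl)cc2)N1`, gives 29.4%.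

All three share a common core carrying a nitro group, a halogenated benzyl sulfide and an anilide, and all were tested as a single oral dose in living rats. Compound 4, `CC1=C(C(=O)Nc2ccc([N+](=O)[O-])cc2)C(c2ccc(Br)cc2)N=C(SCc2ccc(F)cc2)N1`, has not yet been measured in this assay.

Compound 2 is obtained from compound 1 by a single change, (fluoro in place of chloro on an aromatic carbon). That change produced a number 2.6 percentage points lower from compound 1 to compound 2 (within the scatter). Compound 4 arises from compound 3 by fluoro in place of chloro on an aromatic carbon; the surroundings of the exchanged atom read the same in both pairs, so the two changes count as the same change. Compound 3 and compound 1 differ in their cores in more than one place, and that difference is not broken down here. Compound 3 sits nearest to compound 1, and the gap between them lies within the usual scatter, as does the gap to compound 2.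

Since the halogen swap shifted compound 1 to compound 2 by an amount within the scatter, a step of similar size is expected from compound 3 to compound 4, namely a number 2.4 percentage points lower from compound 3 to compound 4 (within the scatter); this expectation rests on a number 2.6 percentage points lower from compound 1 to compound 2 (within the scatter). Compound 4 is therefore estimated to give 27%, with a likely range from 15% to 39%.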

Compound 4, a percentage reported as inhibition, in the whole organism at one dose (the size of the read-out at that dose, not a potency): 27.3%
Estimate against measurement, compound 4: 0.3 percentage points below; low and high end bracket the measured number.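

In this assay, putting fluoro in place of chloro on the benzyl group of the core of compound 3 gave a number 2.1 percentage points lower from compound 3 to compound 4 (within the scatter). Set beside the same exchange on the core of compound 1, the two steps agree, so on these two cores the change carried over with about the same small size: the same change on two cores in this assay, a number 2.6 percentage points lower (within the scatter) from compound 1 to compound 2 and a number 2.1 percentage points lower (within the scatter) from compound 3 to compound 4, 0.5 percentage points apart, within the scatter of two such steps. Among these compounds, this does not show that the exchange has a real effect, since each step lies within the scatter and a small true shift could not be told apart from none; it also covers only two cores, and one oral dose at one stated time gives the size of a read-out, not a potency, so nothing follows for other cores or other doses.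

The compounds shown hold only chloro and fluoro at this place, which leaves open what a group of another kind on the same aromatic carbon, such as an amine, a carboxylic acid or a longer chain, would do to the read-out. On these data alone, compound 1 and compound 3 also differ in more than one place, so the share of the bromo and nitro groups in their printed numbers remains open too.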